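Swapping Methoxy for Methyl on Compound 2

The compounds below may be only part of what the source reports. "The series", "measured", "known", "first", "only" and "open" are said of these compounds alone.

Compound 1 `COc1ccc(CN(C(C)=O)c2cc(OC)c(OC)c(OC)c2)cc1O`: 160 nM
Compound 2 `C/C=C/C(=O)N(Cc1ccc(OC)c(OC)c1)c1cc(OC)c(OC)c(OC)c1`: 39100 nM
Compound 3 `COC(=O)c1cc(CNc2cc(OC)c(OC)c(OC)c2)ccc1OC`: 41100 nM

All three compounds were tested in a functional assay on KYSE-450 cells (Homo sapiens) for inhibition, read by MTT assay, with a stated time of 48 h; on this read-out higher numbers stand for weaker inhibition and lower numbers for stronger inhibition. Among them, compound 2 at 39100 nM and compound 3 at 41100 nM lie within the usual scatter of each other, so the data set no order between them. Compound 1 at 160 nM gives a far lower number than compound 2, a gap well beyond the scatter.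

The next compound is compound 4 `C/C=C/C(=O)N(Cc1ccc(OC)c(C)c1)c1cc(OC)c(OC)c(OC)c1`, which carries methyl in place of methoxy on an aromatic carbon of compound 2, ortho to a methoxy group and meta to a large group: methyl in place of methoxy on an aromatic carbon. Among the measured compounds shown here, no pair of measured compounds differs in only one place, so this change has no direct precedent here. Compound 1 differs from compound 2 in more than one place, and its low number cannot be assigned to any single feature. With no evidence for a shift in either direction, the expected outcome in this assay is no change beyond the scatter, with compound 2 as the only anchor. The estimated 1.3-fold lower number from compound 2 to compound 4 (0.12 log units; within the scatter) is therefore expected to remain small. For compound 4 the estimate is 30000 nM, with an expected range from 8000 nM to 90000 nM.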

Compound 4, half-maximal inhibitory concentration: 32900 nM
Beside the measured number, compound 4's estimate is 1.1-fold (0.04 log units) below it; the range from low to high includes it.
By their numbers in this assay, from the lowest: compound 1; then compounds 4, 2 and 3 (each within the scatter of the next).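

In this assay, among the compounds shown here, the swap of methoxy for methyl on an aromatic carbon, ortho to a methoxy group and meta to a large group, gives the first step in this set that can be read in one place: a 1.2-fold lower number from compound 2 to compound 4 (0.07 log units; within the scatter). For the compounds shown here, at this position, then, the group can lose one oxygen and one hydrogen-bond acceptor without any shift beyond the scatter, which the earlier compounds, all differing from one another in more than one place, could not show. Nothing at hand explains why the number holds through this change.

From the compounds shown here alone, what the other groups would do on this same aromatic carbon stays open: an amine, a carboxylic acid, a chlorine atom or a longer chain such as ethoxy could each give a different answer from methyl. Going by these compounds, it is also open whether the same swap would leave the number in place on the core of compound 1, which gives 160 nM, a value that still cannot be tied to any single feature of its structure.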